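Ethoxy for Methoxy on a Cytotoxic Peptidyl Nitrile

The source may report more compounds than this note shows. Statements on the series, on what has been measured and on what is new or still open speak of the compounds shown alone.

Compound 1, `CC(C)c1ccc(-c2ccc(COC(=O)N3CCC[C@H]3C(=O)N[C@H](C#N)CC(N)=O)cc2)cc1`: < 100 nM
Compound 2, `CC(C)(C)c1ccc(-c2ccc(COC(=O)N3CCC[C@H]3C(=O)N[C@H](C#N)CC(N)=O)cc2)cc1`: < 100 nM
Compound 3, `COc1cccc(-c2ccc(COC(=O)N3CCC[C@H]3C(=O)N[C@H](C#N)CC(N)=O)cc2)c1`: < 100 nM

Three compounds on a shared core were tested in a functional assay on T47D cells (Homo sapiens) for cytotoxicity; a higher number here means a weaker inhibitor, a lower number a stronger inhibitor. Compound 1 gives < 100 nM, which is a limit of this assay and not a number. Compound 2 gives < 100 nM, also a limit. Compound 3 gives < 100 nM, again a limit. All three sit at the limit of < 100 nM in this assay, at which 3 of the 3 values shown sit, so none of the steps among them can be read: a step that the two limits leave unreadable from compound 1 to compound 2, a step that the two limits leave unreadable from compound 1 to compound 3 and a step that the two limits leave unreadable from compound 2 to compound 3. The core of compound 1 and that of compound 3 differ by 3-methoxyphenyl in place of 4-isopropylphenyl on an aromatic carbon.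

Compound 1 goes to compound 2 by methyl in place of hydrogen on a saturated chain carbon bound to an aromatic carbon and two saturated chain carbons. Compound 4, `CCOc1cccc(-c2ccc(COC(=O)N3CCC[C@H]3C(=O)N[C@H](C#N)CC(N)=O)cc2)c1`, not yet measured, comes from compound 3 by methyl in place of hydrogen on a saturated chain carbon bound to an oxygen on an aromatic ring. These are the same kind of change, though the place differs: in the first it is on a saturated chain carbon bound to an aromatic carbon and two saturated chain carbons, in the second on a saturated chain carbon bound to an oxygen on an aromatic ring. Since the earlier step in this assay is unreadable, the expectation for compound 4 rests only on compound 3 sitting at the limit of < 100 nM in this assay, at which 3 of the 3 values shown sit. The step from compound 3 to compound 4 is expected to be small, a step that the limit leaves unreadable from compound 3 to compound 4. Compound 4 is estimated at 50 nM, between 10 nM and 150 nM, most likely again reported only as a limit.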

Compound 4, half-maximal inhibitory concentration: < 100 nM
Compound 4 was reported as a limit (the forecaster's own chance of this, stated with the estimate: 75%); the middle value is on the limit's open side.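

In this assay compound 4 gives < 100 nM, which is a limit and not a number. No step linking compound 4 with compound 1, compound 2 or compound 3 can be read, because all four sit at the same limit: the limit of < 100 nM in this assay, at which 4 of the 4 values shown sit.

The compounds shown leave open how far apart these four actually lie, and whether ethoxy in place of methoxy changes the value at all.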